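The compounds below may be only part of what the source reports. "The series", "measured", "known", "first", "only" and "open" are said of these compounds alone.

Going by the values given here, in a physicochemical assay for solubility, measured as kinetic solubility (a higher number here means a more soluble compound, a lower number a less soluble compound), compound 2 (`Cc1cc2c(Oc3cnc(C(=O)N(C)C)cn3)cc(C(=O)Nc3cnccn3)cc2o1`) gives 30000 nM, the lower of the two numbers measured so far. Compound 1 (`Cc1cnc(NC(=O)c2cc(Oc3cnc(C(=O)N(C)C)cn3)c3cc(C)oc3c2)cn1`) gives 176000 nM. Among the compounds with values here, the only measured step is a 5.9-fold lower number from compound 1 to compound 2 (0.77 log units; beyond the scatter), hydrogen in place of methyl on an aromatic carbon. Compound 3 (`COc1cnc(NC(=O)c2cc(Oc3cnc(C(=O)N(C)C)cn3)c3cc(C)oc3c2)cn1`) has not yet been measured. It differs from compound 2 by methoxy in place of hydrogen on an aromatic carbon, going from pyrazin-2-yl to 5-methoxypyrazin-2-yl: methoxy in place of hydrogen on an aromatic carbon. The carbon involved is the one that carries methyl in compound 1, so that single step is the nearest guide, though methyl and methoxy are different groups and the evidence is thin. Read backwards, it points to a rise of modest size. The expected step is a 2.3-fold higher number from compound 2 to compound 3 (0.37 log units; beyond the scatter). For compound 3 the estimated value is 70000 nM, with an expected range of 20000 nM to 200000 nM.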

Compound 3, solubility: 25000 nM
Estimate against measurement, compound 3: 2.8-fold (0.45 log units) above; the measured number falls inside the stated range.
By their numbers in this assay, from the lowest: compounds 3 and 2 (each within the scatter of the next); then compound 1.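

In this assay, going from pyrazin-2-yl to 5-methoxypyrazin-2-yl gives a 1.2-fold lower number from compound 2 to compound 3 (0.08 log units; within the scatter) and so does not separate methoxy from hydrogen on this aromatic carbon. Methyl on the same carbon does stand apart, with methoxy in place of methyl giving a 7.0-fold lower number from compound 1 to compound 3 (0.85 log units; beyond the scatter) in line with a 5.9-fold lower number from compound 1 to compound 2 (0.77 log units; beyond the scatter) for hydrogen in place of methyl, so of the three groups seen here only the methyl of compound 1 carries the high number. Nothing available here accounts for the difference between methyl and methoxy at this carbon.

The compounds shown leave open whether an ethyl group or a cyclopropyl group would give a number like that of methyl. They also leave open where chlorine, an amine or a nitrile would fall on this carbon.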